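Swapping the aryl amine for a pyrazole amine

This account rests on a few compounds, and the source may have more. Where it says the series, first, only, none or still open, it means among the compounds named here.

Among the measured compounds shown here, compound 1, with the structure `COc1ncc(-c2ccc3ncnc(Nc4ccc(OCCO)cc4)c3c2)cc1NS(C)(=O)=O`, is one of two compounds measured in a functional assay on A549 cells (Homo sapiens) for antiproliferative activity, read by sulforhodamine B assay, with a stated time of 72 h; a lower number here means a stronger inhibitor, a higher number a weaker inhibitor. Compound 1 gives 5200 nM, the lower of the two numbers, while compound 2, with the structure `COc1ncc(-c2ccc3ncnc(Nc4ccc(OCCO)c(F)c4)c3c2)cc1NS(=O)(=O)c1ccc(F)cc1F`, gives 6640 nM in this assay; the gap between them lies within the scatter, so the two show the same activity.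

Compound 3, with the structure `COc1ncc(-c2ccc3ncnc(Nc4cnn(CCCO)c4)c3c2)cc1NS(C)(=O)=O`, has not yet been measured. Its structure differs from compound 1 in one place: 1-(3-hydroxypropyl)-1H-pyrazol-4-yl in place of 4-(2-hydroxyethoxy)phenyl on a nitrogen on an aromatic ring. For the measured compounds named here, no measured pair shows what this kind of change does here, so the expectation rests only on the values of compound 1 and compound 2.

The step of a 1.5-fold higher number from compound 1 to compound 3 (0.19 log units; within the scatter) is expected to be small, a slight loss if anything, barely beyond the scatter. Compound 3 is therefore estimated at 8000 nM in this assay, with a range from 2500 nM to 25000 nM.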

Compound 3, half-maximal inhibitory concentration: 3600 nM
The estimate for compound 3 lay 2.2-fold (0.35 log units) above the measured number; the measured number falls inside the stated range.
By their numbers in this assay, from the lowest: compounds 3, 1 and 2 (each within the scatter of the next).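

In this assay, placing 1-(3-hydroxypropyl)-1H-pyrazol-4-yl on this nitrogen in place of 4-(2-hydroxyethoxy)phenyl gives a 1.4-fold lower number from compound 1 to compound 3 (0.16 log units; within the scatter) and so leaves activity unchanged. Among the compounds shown here, this is the only one-place comparison available so far, and it shows that a six-membered aromatic ring of carbon only can be exchanged here for a five-membered aromatic ring with 2 hetero atoms with no difference beyond the scatter. Nothing measured on these groups bears on this result, so it remains without an explanation.

On these data alone, the swap alters the ring and the hydroxyl-bearing chain together, so the contribution of each remains unknown. An amine or a carboxylic acid in place of the terminal hydroxyl, or a longer chain on the pyrazole, would test whether this position responds to any change in that chain.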